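This account rests on a few compounds, and the source may have more. Where it says the series, first, only, none or still open, it means among the compounds named here.

Working notes on the series. Of the compounds shown here, three with a shared core have been measured: compound 1 `CCCCCCCCc1ccc(OCC(=O)Cn2cnc3ccccc32)cc1`, compound 2 `CCCCCCCCc1ccc(OCC(=O)Cn2ncc3cccnc32)cc1` and compound 3 `CCCCCCCCc1ccc(OCC(=O)Cn2nnc3cccnc32)cc1`. In an assay on microsomes from brain for inhibition of Fatty-acid amide hydrolase 1 (Rattus norvegicus), read by fluorescence and HPLC, with a stated time of 60 min (on this read-out lower numbers stand for stronger inhibition and higher numbers for weaker inhibition), compound 1 gives 480 nM, compound 2 gives 1600 nM and compound 3 gives 13 nM. Compound 3 stands lowest of the three numbers, with a 37-fold lower number from compound 1 to compound 3 (1.57 log units; beyond the scatter) and a 120-fold lower number from compound 2 to compound 3 (2.09 log units; beyond the scatter); the remaining measured step is a 3.3-fold higher number from compound 1 to compound 2 (0.52 log units; beyond the scatter).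

Compound 4 `CCCCCCCCc1ccc(OCC(=O)Cn2nnc3ncccc32)cc1` is not yet measured. It differs from compound 3 by a group of 9 heavy atoms (5 carbon, 4 nitrogen; one five-membered aromatic ring with 3 hetero atoms, one six-membered aromatic ring with 1 hetero atom) in place of a group of 9 heavy atoms (5 carbon, 4 nitrogen; one five-membered aromatic ring with 3 hetero atoms, one six-membered aromatic ring with 1 hetero atom), on a saturated chain carbon bound to a carbonyl carbon. The two have the same atoms, joined differently. For the measured compounds named here, no measured step rearranges a group while keeping its atoms, so none bears directly on this change. The steps into compound 3 show that the group on the saturated chain carbon bound to the carbonyl carbon can move this assay a great deal, and the step from compound 1 to compound 2 shows that altering the six-membered ring alone moves the number modestly. A moderate step toward a higher number, with wide uncertainty, is therefore expected, a 3.1-fold higher number from compound 3 to compound 4 (0.49 log units; beyond the scatter). Compound 4 is estimated at 40 nM in this assay, with a range from 8 nM to 250 nM.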

Compound 4, half-maximal inhibitory concentration: 49 nM
For compound 4 the middle estimate is 1.2-fold (0.09 log units) below the measured one, and the stated range covers the measured number.
By their numbers in this assay, from the lowest: compound 3; then compound 4; then compound 1; then compound 2.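

In this assay the same atoms joined differently on the saturated chain carbon bound to a carbonyl carbon give a 3.8-fold higher number from compound 3 to compound 4 (0.58 log units; beyond the scatter) and so show that the arrangement within this group matters on its own, even with its atoms and counted hydrogen-bond acceptors unchanged. The larger gains survive the rearrangement, with a 33-fold lower number from compound 2 to compound 4 (1.51 log units; beyond the scatter) and a 9.8-fold lower number from compound 1 to compound 4 (0.99 log units; beyond the scatter) in the same assay, and among these four compounds both groups with three hetero atoms in the five-membered ring give lower numbers than both groups with two. The data shown offer no measured explanation for the difference between the two arrangements.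

From the compounds shown here alone, it remains open whether a methyl group or a chlorine atom on the six-membered ring of either group would hold the low number. Also open, going by these compounds, is whether a longer chain on the shared core would preserve the order of compound 3 and compound 4.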